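Swapping Chlorine for Fluorine on the Benzyl Ring

The source may hold more compounds than are shown below. What is called first, only, known or untested is meant among the compounds shown, and "the series" means these compounds.

In a functional assay on the whole organism (artery, strain albino) with Rattus norvegicus as the target, with a stated time of 15 min, at a dose of 10 mg/kg by the oral route (a higher number here means more inhibition at the dose given (going by the name of the read-out), a lower number less inhibition), compound 2 `CC1=C(C(=O)Nc2ccc([N+](=O)[O-])cc2)C(c2ccc(Br)cc2)N=C(SCc2ccc(Cl)cc2)N1` gives 3.1%, and compound 1 `CC1=C(C(=O)Nc2ccc([N+](=O)[O-])cc2)C(c2ccc(Br)cc2)N=C(SCc2cccc(Cl)c2)N1` gives 2.1%, so the two numbers sit within the scatter of each other. Within the data shown here, the only measured step is a number 1 percentage points higher from compound 1 to compound 2 (within the scatter). Compound 3 `CC1=C(C(=O)Nc2ccc([N+](=O)[O-])cc2)C(c2ccc(Br)cc2)N=C(SCc2ccc(F)cc2)N1` differs from compound 2 thus: fluoro in place of chloro on an aromatic carbon. That earlier step also altered the chlorophenyl group on the sulfur-bound benzyl chain and showed nothing beyond the scatter, so no step beyond the scatter is expected here either. Compound 3 is therefore estimated to give 3%, with a range from 0% to 10%. The expected step is a number 0.1 percentage points lower from compound 2 to compound 3 (within the scatter).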

Compound 3, a percentage reported as inhibition, in the whole organism at one dose (the size of the read-out at that dose, not a potency): 2.6%
The estimate for compound 3 lay 0.4 percentage points above the measured number; the range from low to high includes it.
By their numbers in this assay, from the lowest: compounds 1, 3 and 2 (each within the scatter of the next).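

In this assay fluoro in place of chloro on this aromatic carbon gives a number 0.5 percentage points lower from compound 2 to compound 3 (within the scatter) and so, at this position, changing the halogen does no more than moving the chlorine did. The 4-fluorophenyl group set against the 3-chlorophenyl group gives a number 0.5 percentage points higher from compound 1 to compound 3 (within the scatter) and that step stays small too. Nothing measured here bears on why these numbers stay so close. From the compounds shown here alone, whether an amine, a carboxylic acid or a methoxy group at this position would give a step beyond the scatter remains open.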